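The compounds below may be only part of what the source reports. "The series", "measured", "known", "first", "only" and "open" are said of these compounds alone.

In a functional assay on HepG2 cells (Homo sapiens) for cytotoxicity, read by sulforhodamine B assay, with a stated time of 48 h (on this read-out lower numbers stand for stronger inhibition and higher numbers for weaker inhibition), compound 1 `O=C(/C=C/c1ccc(Br)cc1)c1cccc(-c2cccc(F)c2)c1` gives 9920 nM and compound 2 `COc1cccc(/C=C/C(=O)c2cccc(-c3cccc(F)c3)c2)c1OC` gives 9200 nM while compound 3 `O=C(/C=C/c1cccc(Br)c1)c1cccc(-c2cccc(F)c2)c1` gives 6980 nM as its reading. These three numbers all lie within the scatter of one another, so compound 3 stands level with the other two. Compound 4 `COc1ccccc1/C=C/C(=O)c1cccc(-c2cccc(F)c2)c1` carries 2-methoxyphenyl in place of 3-bromophenyl on a double-bonded chain carbon bound to a double-bonded chain carbon. For the measured compounds named here, the one measured step on the bromophenyl group (a 1.4-fold lower number from compound 1 to compound 3 (0.15 log units; within the scatter)) stays within the scatter. Compound 2 also carries methoxy at this place and its 9200 nM lies within the scatter of compound 3. Going by the values given here, no measured compound carries 2-methoxyphenyl itself, so the read-across is limited. No step beyond the scatter is therefore expected in this assay and no direction is favoured. The estimated step is small (a 1.1-fold higher number from compound 3 to compound 4 (0.06 log units; within the scatter)). For compound 4 the expected value is 8000 nM with an estimated range from 3500 nM to 18000 nM in this read-out.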

Compound 4, half-maximal inhibitory concentration: 15400 nM
For compound 4 the middle estimate is 1.9-fold (0.28 log units) below the measured one, within the range that was stated.
By their numbers in this assay, from the lowest: compounds 3, 2, 1 and 4 (each within the scatter of the next, the first and the last beyond it).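

In this assay, for the compounds shown here, a 2.2-fold higher number from compound 3 to compound 4 (0.34 log units; beyond the scatter) is the first step at this place to pass beyond the scatter, though it is only modest. The same group gives no separation from the other two compounds: a 1.6-fold higher number from compound 1 to compound 4 (0.19 log units; within the scatter) and a 1.7-fold higher number from compound 2 to compound 4 (0.22 log units; within the scatter) both stay within the scatter, the second being the change of hydrogen in place of methoxy on an aromatic carbon, so 2-methoxyphenyl stands apart from 3-bromophenyl alone. No supporting data bear on the reason for this step.

Going by these compounds, all four compounds carry only bromine or methoxy on the ring at this place, so it remains open whether a larger step can be had here in this assay. An amine or a carboxylic acid on that ring would test this in either direction.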